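The compounds below may be only part of what the source reports. "The series", "measured", "known", "first", "only" and "open" are said of these compounds alone.

Compound 2 `O[C@H]1CC[C@H](Nc2ccc(-c3ccn4c(CC5CC5)nnc4c3Cl)cc2Cl)CC1` gives the lowest of the two numbers in an assay on cells for displacement of a labelled ligand from metabotropic glutamate receptor 2 (Homo sapiens), read by scintillation counting, with a stated time of 60 min (a lower number here means a stronger inhibitor, a higher number a weaker inhibitor), at 3.02 nM; compound 1 `Clc1cc(-c2ccn3c(CC4CC4)nnc3c2Cl)ccc1NC1CC1` gives 6.76 nM, and the step of a 2.2-fold lower number from compound 1 to compound 2 (0.35 log units; beyond the scatter) alters only the group on a nitrogen on an aromatic ring. Compound 3 `O[C@H]1CC[C@H](Nc2ccc(-c3ccn4c(CC(F)(F)F)nnc4c3Cl)cc2Cl)CC1` keeps that group and instead carries the change (trifluoromethyl in place of cyclopropyl on a saturated chain carbon bound to an aromatic carbon). Within the data shown here, no measured step touches this saturated chain carbon, so the only guide is the modest size of the one known step. Compound 3 is therefore expected to give a step of a 1.5-fold higher number from compound 2 to compound 3 (0.17 log units; within the scatter), an estimated value of 4.5 nM within a range from 1.5 nM to 14 nM.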

Compound 3, inhibition constant: 6.03 nM
Compound 3: middle estimate off by 1.3-fold (0.13 log units), on the low side; the measured number falls inside the stated range.
By their numbers in this assay, from the lowest: compounds 2, 3 and 1 (each within the scatter of the next, the first and the last beyond it).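

In this assay, among these compounds, the earlier compounds kept cyclopropylmethyl fixed, and this change at the saturated chain carbon gives a 2.0-fold higher number from compound 2 to compound 3 (0.30 log units; within the scatter), so cyclopropylmethyl and 2,2,2-trifluoroethyl cannot be told apart here. This place therefore carries trifluoromethyl, with no ring, as well as cyclopropyl, without a step beyond the scatter. No available evidence accounts for this reading.

Whether a longer chain, a phenyl ring or an amine at this carbon would keep the number open, and whether the same swap would read alike with the cyclopropyl on a nitrogen of compound 1, remains unsettled.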